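This account rests on a few compounds, and the source may have more. Where it says the series, first, only, none or still open, it means among the compounds named here.

Compound 1 (`CC(C)CC(=O)NC(=O)c1c[nH]c([C@@H](O)c2ccccc2)cc1=O`) and compound 2 (`NC(=O)c1cn(CCO)c([C@@H](O)c2ccccc2)cc1=O`) share the same core, each shown with its structure. In a functional assay on A549 cells (Homo sapiens) for inhibition, read by sulforhodamine B assay, with a stated time of 48 h (on this read-out higher numbers stand for weaker inhibition and lower numbers for stronger inhibition), compound 1 gives > 50000 nM, which is a limit of the assay and not a measured number. In this assay compound 2 likewise gives > 50000 nM, again a limit rather than a number. Both values thus sit at the limit of > 50000 nM in this assay, at which 2 of the 2 values shown sit, so compound 2 cannot be placed above or below compound 1 on these figures. Compound 3 (`CC(C)CC(=O)NC(=O)c1cn(CCO)c([C@@H](O)c2ccccc2)cc1=O`) is the next member. The change from compound 2 to compound 3 is isobutylcarbonyl in place of hydrogen on an amide-type nitrogen. Because compound 1 already carries this isobutylcarbonyl group on its amide nitrogen and gives > 50000 nM, the step that the limit leaves unreadable from compound 2 to compound 3 is expected to be none beyond the scatter, with the limit most likely reached again. Compound 3 is therefore estimated at 60000 nM, within 20000 nM to 200000 nM.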

Compound 3, half-maximal inhibitory concentration: > 50000 nM
Compound 3 gave a limit, no number; the forecaster's own chance of this, stated with the estimate: 85%; the middle value does not contradict the limit.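

In this assay, for the compounds shown here, compound 3 gives > 50000 nM, again a limit and not a number, so no step among compound 1, compound 2 and compound 3 can be read: the limit of > 50000 nM in this assay, at which 3 of the 3 values shown sit. The compounds shown leave open what effect on inhibition, if any, the isobutylcarbonyl and 2-hydroxyethyl changes have.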